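The source may report more compounds than this note shows. Statements on the series, on what has been measured and on what is new or still open speak of the compounds shown alone.

In a functional assay on A549 cells (Homo sapiens) for antiproliferative activity, read by MTT assay, with a stated time of 72 h (on this read-out higher numbers stand for weaker inhibition and lower numbers for stronger inhibition), three amides built on one shared core have been measured. Compound 1 `Cc1nc(C(=O)Nc2ccc(Cl)c(-c3nnc4c(Cl)cccn34)c2)cs1` reaches only the limit of this assay, > 100000 nM. Compound 2 `O=C(Nc1ccc(Cl)c(-c2nnc3c(Cl)cccn23)c1)c1c(F)cccc1Cl` gives 72300 nM in this assay. Compound 3 `O=C(Nc1ccc(Cl)c(-c2nnc3c(Cl)cccn23)c1)c1ccccc1Cl` likewise reaches only the limit, > 100000 nM. Compound 3 therefore sits at the limit of > 100000 nM in this assay, at which 2 of the 3 values shown sit. Among the measured compounds shown here, the only readable step to compound 3 is an at least 1.3-fold higher number from compound 2 to compound 3 (0.14 log units; that floor lies within the scatter); the step that the two limits leave unreadable from compound 1 to compound 3 cannot be read, and an at least 1.3-fold lower number from compound 1 to compound 2 (0.14 log units; that floor lies within the scatter) is small. Compound 4 `O=C(Nc1ccc(Cl)c(-c2nnc3c(Cl)cccn23)c1)c1cccnc1Cl` differs from compound 3 by 2-chloropyridin-3-yl in place of 2-chlorophenyl on a carbonyl carbon. For the measured compounds named here, no measured step exchanges a ring of carbon only for a ring with one hetero atom at this position, so nothing measured bears directly on the change; the steps that do alter the group on the carbonyl carbon all lie within the scatter. For compound 4 the expected step is a number no higher from compound 3 to compound 4 (the limit leaves the size open), none beyond the scatter. Compound 4 is estimated at 100000 nM in this assay, with a range from 40000 nM to 250000 nM.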

Compound 4, half-maximal inhibitory concentration: 35800 nM
Beside the measured number, compound 4's estimate is 2.8-fold (0.45 log units) above it; the whole stated range lies above it.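

Among the compounds shown here, at this position, on a carbonyl carbon, a change of ring now moves the number beyond the scatter in this assay, which no earlier step did: 2-chloropyridin-3-yl in place of 2-chlorophenyl gives an at least 2.7-fold lower number from compound 3 to compound 4 (0.44 log units; beyond the scatter), a change that enters one ring nitrogen and leaves the heavy-atom count unchanged. The same group also separates compound 4 from the other two amides, with a 2.0-fold lower number from compound 2 to compound 4 (0.31 log units; beyond the scatter) and an at least 2.7-fold lower number from compound 1 to compound 4 (0.44 log units; beyond the scatter), so compound 4 is the most potent of the four. Two of these three steps start from a limit and so give only a floor on their size: the limit of > 100000 nM in this assay, at which 2 of the 4 values shown sit.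

The compounds shown leave open whether the effect follows the ring nitrogen alone. They also leave open how an amine or a carboxylic acid on the 2-chloropyridin-3-yl ring would read.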